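Pyridin-2-yl in Place of 4-Methylphenyl: Expected Inhibition

A few compounds are considered here, and "the series" means these few. Any claim that something is new, unique, unknown or untested is made for them only; others in the source may bear on it.

Measured so far:
compound 1 `Cc1ccc(-c2cc(C(=O)N3CCC4(CC3)CC(=O)c3nn(C(C)(C)C)cc3O4)c3ccccc3n2)cc1` — > 10000 nM
compound 2 `CC(C)(C)n1cc2c(n1)C(=O)CC1(CCN(C(=O)c3cc(-c4ccc(F)cc4)nc4ccccc34)CC1)O2` — > 10000 nM

In a functional assay on MDA-MB-231 cells (Homo sapiens) for inhibition, read by MTT assay, with a stated time of 72 h (a lower number here means a stronger inhibitor, a higher number a weaker inhibitor), compound 1 gives only a limit, > 10000 nM. Compound 2 likewise gives only a limit there, > 10000 nM. Both values sit at the limit of > 10000 nM in this assay, at which 2 of the 2 values shown sit, so the step that the two limits leave unreadable from compound 1 to compound 2 cannot be read. Compound 3 `CC(C)(C)n1cc2c(n1)C(=O)CC1(CCN(C(=O)c3cc(-c4ccccn4)nc4ccccc34)CC1)O2` differs from compound 1 by pyridin-2-yl in place of 4-methylphenyl on an aromatic carbon. No measured step bears readably on this change, and nothing shown places compound 1 inside the measurable range. Compound 3 is therefore expected to remain at the limit as well, estimated at 20000 nM (range 8000 nM to 60000 nM), a step that the limit leaves unreadable from compound 1 to compound 3.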

Compound 3, half-maximal inhibitory concentration: 8100 nM
The estimate for compound 3 lay 2.5-fold (0.39 log units) above the measured number, and the stated range covers the measured number.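

On this aromatic carbon next to the ring nitrogen, pyridin-2-yl gives the first value shown inside the measurable range of this assay: compound 3 reads 8100 nM. The steps are an at least 1.2-fold lower number from compound 1 to compound 3 (0.09 log units; that floor lies within the scatter) and an at least 1.2-fold lower number from compound 2 to compound 3 (0.09 log units; that floor lies within the scatter), so the change is not yet shown to exceed the scatter. The true size of both steps stays unreadable: the limit of > 10000 nM in this assay, at which 2 of the 3 values shown sit.

Whether the ring nitrogen of pyridin-2-yl carries any difference is not settled by the compounds shown. Pyridin-3-yl and pyridin-4-yl at this position remain open, as does a phenyl ring bearing an amine or a carboxylic acid.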